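The source may hold more compounds than are shown below. What is called first, only, known or untested is meant among the compounds shown, and "the series" means these compounds.

Measured in an ADME assay on L6 cells (Rattus norvegicus) for cytotoxicity, read by resazurin assay, with a stated time of 72 h; a higher number here means a weaker inhibitor, a lower number a stronger inhibitor:

- compound 1 `OC(c1ccc(Cl)cc1)(c1ccc(Cl)cc1)c1cncnc1`: 47200 nM
- compound 2 `CC(C)CNC(c1ccc(Cl)cc1)(c1cccnc1)c1ccccc1Cl`: 59200 nM
- compound 3 `OC(c1ccc(Cl)cc1)(c1cccnc1)c1ccccc1C(F)(F)F`: 59300 nM

All three numbers sit close together. Compound 1 gives the lowest of the three, but its gaps to compound 2 and to compound 3 are both within the scatter, so no order among them can be read from this assay. No pair of these compounds differs in only one place, so no single-change step is available as a guide.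

Compound 4 `OC(c1ccc(Cl)cc1)(c1cccnc1)c1cncnc1` is not yet measured. It differs from compound 1 in one place: pyridin-3-yl in place of 4-chlorophenyl on a saturated chain carbon bound to two aromatic carbons and an oxygen on a saturated carbon. Among the compounds with values here, with no comparable step on hand, the expectation for this assay is a step from compound 1 to compound 4 of a 1.3-fold higher number from compound 1 to compound 4 (0.10 log units; within the scatter), that is, none beyond the scatter or at most a small one. Compound 4 is estimated at 60000 nM, within a range of 30000 nM to 120000 nM.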

Compound 4, half-maximal inhibitory concentration: > 100000 nM
Compound 4 was reported as a limit; the forecaster's own chance of this, stated with the estimate: 25%; middle value at least 1.6-fold (0.22 log units) away from the limit.
By their numbers in this assay, from the lowest: compounds 1, 2 and 3 (each within the scatter of the next). At a limit, above all of these: compound 4.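

In this assay, pyridin-3-yl in place of 4-chlorophenyl on a saturated chain carbon bound to two aromatic carbons and an oxygen on a saturated carbon gives an at least 2.1-fold higher number from compound 1 to compound 4 (0.32 log units; beyond the scatter). Within the data shown here, this is the first single-change step, and it lies beyond the scatter. Compound 4 stands at a limit of the assay, so the step is a minimum and its full size is unknown: the limit of > 100000 nM in this assay, at which 1 of the 4 values shown sits.

The compounds shown do not separate the loss of chlorine from the gain of a ring nitrogen. Unsubstituted phenyl at this place would separate the two.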